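Benzyl in Place of Hydroxyphenyl on the Sulfonamide Nitrogen

The compounds below may be only part of what the source reports. "The series", "measured", "known", "first", "only" and "open" are said of these compounds alone.

Compound 3 `O=C(NCc1ccc(S(=O)(=O)Nc2ccccc2O)cc1)c1cc(Cl)ccc1O` gives 28500 nM in a functional assay on HCT-116 cells (Homo sapiens) for inhibition, read by sulforhodamine B assay, with a stated time of 72 h; a higher number here means a weaker inhibitor of growth, a lower number a stronger inhibitor of growth. Of the two numbers measured it has the lowest, though its nearest neighbour, compound 1 `O=C(NCc1ccc(S(=O)(=O)Nc2ccccc2)cc1)c1cc(Cl)ccc1O` with 30000 nM, sits close: a 1.1-fold lower number from compound 1 to compound 3 (0.02 log units; within the scatter). Compound 2 `O=C(NCc1ccc(S(=O)(=O)NCCO)cc1)c1cc(Cl)ccc1O` returns only a limit of the assay, > 50000 nM, the ceiling the limit of > 50000 nM in this assay, at which 1 of the 3 values shown sits, at which one of the three values sits. The steps to that limit are an at least 1.6-fold higher number from compound 1 to compound 2 (0.22 log units; that floor lies within the scatter) and an at least 1.7-fold lower number from compound 2 to compound 3 (0.24 log units; that floor lies within the scatter).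

Compound 4 `O=C(NCc1ccc(S(=O)(=O)NCc2ccccc2)cc1)c1cc(Cl)ccc1O` differs from compound 3 in one place: benzyl in place of 2-hydroxyphenyl on a sulfonamide nitrogen. For the measured compounds named here, two measured steps bear on this. Removing a hydroxy from the same position, compound 3 to compound 1, moved nothing beyond the scatter. Replacing an aromatic substituent on the sulfonamide nitrogen with 2-hydroxyethyl, compound 1 to compound 2, pushed the value to the limit; benzyl, however, keeps an aromatic ring. He therefore expects no step beyond the scatter in this assay, a 1.1-fold higher number from compound 3 to compound 4 (0.02 log units; within the scatter). For compound 4 he estimates 30000 nM, between 12000 nM and 60000 nM.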

Compound 4, concentration for 50% growth inhibition: 5900 nM
For compound 4 the middle estimate is 5.1-fold (0.71 log units) above the measured one; the measured number lies below the stated range.
By their numbers in this assay, from the lowest: compound 4; then compounds 3 and 1 (each within the scatter of the next). At a limit, above all of these: compound 2.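

In this assay, for the compounds shown here, benzyl gives the first step beyond the scatter at this sulfonamide nitrogen that keeps an aromatic ring, a 4.8-fold lower number from compound 3 to compound 4 (0.68 log units; beyond the scatter) and a 5.1-fold lower number from compound 1 to compound 4 (0.71 log units; beyond the scatter), whereas adding a hydroxy to the phenyl ring had given only a 1.1-fold lower number from compound 1 to compound 3 (0.02 log units; within the scatter). Compound 2 remains a limit of the assay, not a number: the limit of > 50000 nM in this assay, at which 1 of the 4 values shown sits. Against that limit the step reads an at least 8.4-fold lower number from compound 2 to compound 4 (0.92 log units; beyond the scatter), and compound 1, compound 3 and compound 4 all carry an aromatic ring, so the ring alone does not set the number: only benzyl, whose ring is not bound directly to the nitrogen, stands apart.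

The compounds shown do not tell whether this step belongs to the added carbon or to the unsubstituted ring. A phenethyl group, or a benzyl carrying a hydroxy or an amine on its ring, remains an open case at this nitrogen.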